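Pyrrolidin-1-yl for Anilino on the Shared Core

This account rests on a few compounds, and the source may have more. Where it says the series, first, only, none or still open, it means among the compounds named here.

Three compounds have been measured in a functional assay on PC-3 cells (Homo sapiens) for inhibition, with a stated time of 72 h; a lower number here means a stronger inhibitor, a higher number a weaker inhibitor:
compound 1 `O=C(Nc1ccc(Cl)cc1)Nc1nc(Sc2c[nH]c3ccccc23)cc(N2CCCC2)n1` gives 10400 nM
compound 2 `O=C(Nc1ccccc1)Nc1nc(Sc2c[nH]c3ccccc23)cc(N2CCCC2)n1` gives 14900 nM
compound 3 `Cc1cc(Cl)ccc1NC(=O)Nc1nc(Nc2ccccc2)cc(Sc2c[nH]c3ccccc23)n1` gives 41900 nM

Compound 3 stands highest of the three numbers; its nearest neighbour is compound 2 and its furthest is compound 1, and both of those gaps lie beyond the scatter. Compound 4 `Cc1cc(Cl)ccc1NC(=O)Nc1nc(Sc2c[nH]c3ccccc23)cc(N2CCCC2)n1` has not yet been measured. It differs from compound 3 in one place: pyrrolidin-1-yl in place of anilino on an aromatic carbon. Among the measured compounds shown here, no measured step covers this exchange directly. For the measured compounds named here, the single recorded step, a 1.4-fold higher number from compound 1 to compound 2 (0.16 log units; within the scatter), concerns the urea aryl group and not the site in question, yet it shows that the two pyrrolidin-1-yl compounds sit close together, while compound 3 with anilino lies above both of them. Compound 4 is therefore expected to move down toward those two, a step of a 3.5-fold lower number from compound 3 to compound 4 (0.54 log units; beyond the scatter) in this assay. The estimate for compound 4 is 12000 nM, with a range from 4500 nM to 32000 nM.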

Compound 4, half-maximal inhibitory concentration: 12900 nM
For compound 4 the middle estimate is 1.1-fold (0.03 log units) below the measured one, and the stated range covers the measured number.
By their numbers in this assay, from the lowest: compounds 1, 4 and 2 (each within the scatter of the next); then compound 3.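

In this assay, among the compounds shown here, the exchange at this position, on the aromatic carbon next to the ring nitrogen, gives a 3.2-fold lower number from compound 3 to compound 4 (0.51 log units; beyond the scatter), the first direct reading of this site, with 4-chloro-2-methylphenyl held constant on the urea. With pyrrolidin-1-yl in place, changing the urea aryl group has no effect beyond the scatter: the replacement of phenyl by 4-chloro-2-methylphenyl gives a 1.2-fold lower number from compound 2 to compound 4 (0.06 log units; within the scatter), and the added methyl gives a 1.2-fold higher number from compound 1 to compound 4 (0.09 log units; within the scatter). Nothing measured here explains the step at this position.

The compounds shown leave open whether this step is particular to pyrrolidin-1-yl or would also follow from piperidin-1-yl, morpholin-4-yl or dimethylamino at this position. They also leave open whether the same exchange gives a step of similar size when phenyl sits on the urea.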